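Chloro for Trifluoromethyl on the Urea Aryl Ring

The source may hold more compounds than are shown below. What is called first, only, known or untested is meant among the compounds shown, and "the series" means these compounds.

Two compounds of this series have so far been run in a functional assay on COLO 205 cells (Homo sapiens) for inhibition, read by sulforhodamine B assay, with a stated time of 48 h, tested at 10 uM; on this read-out higher numbers stand for a weaker effect at the one concentration tested and lower numbers for a stronger effect. Compound 1 `COc1cc(Cl)cc(-c2nn(-c3cccc(NC(=O)c4ccc(Cl)c(Cl)c4)c3)cc2-c2ccncc2)c1`, which carries an amide, gives 81.5% in this assay. Compound 2 `O=C(Nc1cccc(-n2cc(-c3ccncc3)c(-c3cc(O)cc(Cl)c3)n2)c1)Nc1ccc(Cl)c(C(F)(F)F)c1`, a urea, gives 63.4% in this assay; this is the lower of the two numbers, and its gap to compound 1 lies beyond the usual scatter.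

Compound 3 `O=C(Nc1cccc(-n2cc(-c3ccncc3)c(-c3cc(O)cc(Cl)c3)n2)c1)Nc1ccc(Cl)c(Cl)c1` has not yet been measured. It differs from compound 2 in a single place: chloro in place of trifluoromethyl on an aromatic carbon. The change sits on an aromatic carbon of a six-membered aromatic ring of carbon only, ortho to a chloro group and meta to a large group, so that the ring reads 3,4-dichlorophenyl, the same ring that compound 1 carries on its amide. Among the measured compounds shown here, no measured pair shows this change, so only the value of compound 2, 63.4%, anchors the expectation. Compound 3 is therefore expected to give about 64% in this assay, between 46% and 82%. The expected step of a number 0.6 percentage points higher from compound 2 to compound 3 (within the scatter) is small, most likely within the scatter, with no clear direction.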

Compound 3, a percentage reported as activity, at one concentration (the size of the read-out at that concentration, not a potency): 22.4%
Compound 3: the middle estimate sits 41.6 percentage points above what was measured; the measured number lies below the stated range.
By their numbers in this assay, from the lowest: compound 3; then compound 2; then compound 1.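

In this assay, chloro in place of trifluoromethyl on this aromatic carbon, ortho to a chloro group, brings a number 41 percentage points lower from compound 2 to compound 3 (beyond the scatter). Among the compounds shown here, this is the only step so far that isolates a single place, and it shows that the urea aryl ring is highly sensitive to what this carbon carries. Here, 4-chloro-3-(trifluoromethyl)phenyl and 3,4-dichlorophenyl are not interchangeable, and the single chlorine atom goes with the stronger effect, but no measurement on hand accounts for the size of this step.

As far as these compounds go, it remains open whether another group on this carbon, such as fluoro, methyl or methoxy, would match chloro or fall back towards trifluoromethyl. Compound 1 differs from compound 3 in more than one place, so the part played by its amide cannot be read from these numbers.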